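The source may hold more compounds than are shown below. What is called first, only, known or untested is meant among the compounds shown, and "the series" means these compounds.

Three compounds share one core and differ only in the group attached to an aromatic carbon. Compound 1 `CCOC(=O)CCCCCOc1cccc(CN(C(=O)c2ccc(-c3ccc(C(C)=O)s3)cc2)C(C)C)c1` carries a 5-acetylthiophen-2-yl group. In an ADME assay on BJ cells (Homo sapiens) for cytotoxicity, read by CellTiter-Glo and resazurin assay, with a stated time of 72 h (on this read-out lower numbers stand for an effect already at smaller amounts and higher numbers for an effect only at larger amounts of compound), compound 1 gives > 26000 nM, which is a limit of the assay and not a number. Compound 2 `CCOC(=O)CCCCCOc1cccc(CN(C(=O)c2ccc(-c3cccc(O)c3)cc2)C(C)C)c1` carries a 3-hydroxyphenyl group in that position. In this assay compound 2 gives > 26000 nM, again only a limit. Compound 3 `CCOC(=O)CCCCCOc1cccc(CN(C(=O)c2ccc(-c3cc(F)cc(OC)c3)cc2)C(C)C)c1` carries a 3-fluoro-5-methoxyphenyl group. In this assay compound 3 gives > 26000 nM, also a limit. The steps a step that the two limits leave unreadable from compound 1 to compound 2, a step that the two limits leave unreadable from compound 1 to compound 3 and a step that the two limits leave unreadable from compound 2 to compound 3 are therefore all of unreadable size, and compound 3 stands together with the other two at the limit of > 26000 nM in this assay, at which 3 of the 3 values shown sit.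

Compound 4 `CCOC(=O)CCCCCOc1cccc(CN(C(=O)c2ccc(-c3cccc(F)c3)cc2)C(C)C)c1` brings the next change: hydrogen in place of methoxy on an aromatic carbon. Among the compounds with values here, none of the measured steps reads as a number, so they give no ground to expect compound 4 to leave the limit where compounds 1 to 3 sit. The step that the limit leaves unreadable from compound 3 to compound 4 is expected to stay within the scatter. Compound 4 is therefore estimated at 30000 nM, within 15000 nM to 60000 nM, and most likely the assay will again report only a limit.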

Compound 4, half-maximal effective concentration: > 26000 nM
Compound 4: no number, only a limit (the forecaster's own chance of this, stated with the estimate: 85%); the middle value lies beyond the limit too.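

In this assay compound 4 gives > 26000 nM, again a limit and not a number. Within the data shown here, no step from compound 1, compound 2 or compound 3 to compound 4 can therefore be read, and all four compounds sit together: the limit of > 26000 nM in this assay, at which 4 of the 4 values shown sit. The compounds shown leave open where any of them would reach a readable value in this assay, and whether their groups differ there at all.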